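The source may hold more compounds than are shown below. What is called first, only, known or untested is meant among the compounds shown, and "the series" means these compounds.

Compound 2 `CO/N=C(/CCN1CCN(c2ccccn2)CC1)c1ccc(Cl)cc1` in a functional assay on HEK293 cells with D(4) dopamine receptor (Homo sapiens) as the target, read by FLIPR (a lower number here means a smaller maximal response, a higher number a larger maximal response), gives 68%. For the measured compounds named here, its only neighbour, compound 1 `CO/N=C(/CCN1CCN(c2ccccn2)CC1)c1ccccc1C`, gives 72% in this assay; the two numbers lie within the scatter of one another, and the step of a number 4 percentage points lower from compound 1 to compound 2 (within the scatter) is the sole measured step in the set. Compound 3 `CO/N=C(/CCN1CCN(c2ccccn2)CC1C)c1ccc(Cl)cc1` has not been measured; it differs from compound 2 by methyl in place of hydrogen on a saturated ring carbon. Going by the values given here, no measured step touches the saturated six-membered ring, so nothing in the data speaks directly to this change. Among the compounds with values here, the one step that is known, at the aryl group on the carbon with a double bond to nitrogen, stayed within the scatter. On that basis no step beyond the scatter is expected from compound 2 to compound 3, no change at the digits printed from compound 2 to compound 3 (within the scatter), and the estimate for compound 3 in this assay is 68%, with a range from 50% to 85% reflecting the absence of any comparable measured step.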

Compound 3, largest response reached (reported as efficacy), in percent of the reference or control that the assay uses: 45%
For compound 3 the middle estimate is 23 percentage points above the measured one; the measured number lies below the stated range.
By their numbers in this assay, from the lowest: compound 3; then compounds 2 and 1 (each within the scatter of the next).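

The saturated ring carbon next to the ring nitrogen is a position that responds in this assay: methyl in place of hydrogen there gives a number 23 percentage points lower from compound 2 to compound 3 (beyond the scatter). For the compounds shown here, this is the only step beyond the scatter, whereas the change at the aryl group, a number 4 percentage points lower from compound 1 to compound 2 (within the scatter), stays within it, so one added carbon on this ring is enough to shift the maximal response. No available evidence accounts for this shift.

The compounds shown leave open whether an ethyl or a hydroxymethyl group on this carbon would lower the response further, retain it or reverse the shift, and whether methyl on another saturated ring carbon would act alike. They also leave open whether the same methyl step holds with the 2-methylphenyl group of compound 1.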